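The compounds below may be only part of what the source reports. "The series", "measured", "known", "first", "only" and "open" are said of these compounds alone.

Compound 1 `CC[C@H](C)[C@H](N)CN(C(=O)[C@@H]1C[C@H]1c1ccccc1)c1ccc(-c2ccc(C(C)(C)C)cc2)cc1`: 750 nM
Compound 2 `CC[C@H](C)[C@H](N)CN(C(=O)[C@@H]1C[C@H]1c1ccccc1)c1ccc(-c2ccc(COC)cc2)cc1`: 35 nM

Within the data shown here, in a functional assay for agonist activity at G protein-coupled receptor 88 (Homo sapiens), read by HTRF and cAMP accumulation (on this read-out higher numbers stand for an effect only at larger amounts of compound and lower numbers for an effect already at smaller amounts), compound 2 holds the lowest of the two numbers; the single measured step, a 21-fold lower number from compound 1 to compound 2 (1.33 log units; beyond the scatter), separates it from compound 1. Compound 3 `CC[C@H](C)[C@H](N)CN(C(=O)[C@@H]1C[C@H]1c1ccccc1)c1ccc(-c2ccc(CCC(=O)OC)cc2)cc1` differs from compound 2 by (methoxycarbonyl)methyl in place of methoxy on a saturated chain carbon bound to an aromatic carbon. That measured step concerned a different exchange on an aromatic carbon, so it bears only loosely on this change, which keeps an oxygen-bearing chain in place. For compound 3 a modest step of a 2.3-fold higher number from compound 2 to compound 3 (0.36 log units; beyond the scatter) is expected, most likely upward. Compound 3 is estimated at 80 nM, within 20 nM to 320 nM.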

Compound 3, half-maximal effective concentration: 110 nM
Compound 3: middle estimate off by 1.4-fold (0.14 log units), on the low side; measured number inside the range.
By their numbers in this assay, from the lowest: compound 2; then compound 3; then compound 1.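

In this assay, going from methoxymethyl to 2-(methoxycarbonyl)ethyl brings a 3.1-fold higher number from compound 2 to compound 3 (0.50 log units; beyond the scatter) and so the longer chain with its carbonyl does not match methoxymethyl at this place. Set against tert-butyl, the same group still gives a 6.8-fold lower number from compound 1 to compound 3 (0.83 log units; beyond the scatter) and so becomes the second oxygen-bearing group on this aromatic carbon to stand clearly under compound 1. Nothing at hand explains this order of the numbers. The compounds shown leave open whether the chain length or the ester sets the rise, and how a carboxylic acid, an amine or a plain propyl chain would read here.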